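Swapping a ring on the amine end of a chemokine-receptor antagonist

The compounds below may be only part of what the source reports. "The series", "measured", "known", "first", "only" and "open" are said of these compounds alone.

Three compounds have been measured in a functional assay on cells for antagonist activity at C-X-C chemokine receptor type 4 (Homo sapiens), read by fluorescence and calcium flux, with stated times of 25 min and 90 s; a higher number here means a weaker inhibitor, a lower number a stronger inhibitor:

Compound 1 `c1ccc2c(c1)CN[C@@H](CN(CCCCNC1CCOCC1)[C@H]1CCCc3cccnc31)C2` gives 29.4 nM
Compound 2 `CC1(C)CCC(NCCCCN(C[C@H]2Cc3ccccc3CN2)[C@H]2CCCc3cccnc32)CC1` gives 77.6 nM
Compound 3 `CC(C)(CCN(C[C@H]1Cc2ccccc2CN1)[C@H]1CCCc2cccnc21)CNC1CCOCC1` gives 36.3 nM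

Compound 1 and compound 2 differ by 4,4-dimethylcyclohexyl in place of oxan-4-yl on an amine nitrogen, and this change made a step of a 2.6-fold higher number from compound 1 to compound 2 (0.42 log units; beyond the scatter). Compound 3 differs from compound 1 in its core by a group of 11 heavy atoms (9 carbon, 1 nitrogen, 1 oxygen; one six-membered non-aromatic ring with 1 hetero atom) in place of a group of 9 heavy atoms (7 carbon, 1 nitrogen, 1 oxygen; one six-membered non-aromatic ring with 1 hetero atom), on a saturated chain carbon, two bonds along the chain from an amine nitrogen, a change that made a step of only a 1.2-fold higher number from compound 1 to compound 3 (0.09 log units; within the scatter). Compound 4 `CC1(C)CCC(NCC(C)(C)CCN(C[C@H]2Cc3ccccc3CN2)[C@H]2CCCc3cccnc32)CC1` has not yet been measured; it differs from compound 3 by 4,4-dimethylcyclohexyl in place of oxan-4-yl on an amine nitrogen, the same change seen between compound 1 and compound 2, at the same kind of place. Because the core change gave a 1.2-fold higher number from compound 1 to compound 3 (0.09 log units; within the scatter), the earlier step is expected to carry over, and a step of about a 2.6-fold higher number from compound 3 to compound 4 (0.41 log units; beyond the scatter) is expected from compound 3 to compound 4. Compound 4 is therefore estimated at 94 nM, likely between 45 nM and 200 nM.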

Compound 4, half-maximal inhibitory concentration: 541 nM
Compound 4: middle estimate off by 5.8-fold (0.76 log units), on the low side; measured number above the stated range.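

On the core of compound 3, 4,4-dimethylcyclohexyl in place of oxan-4-yl weakens inhibition much more than it did on the core of compound 1, with a step of a 15-fold higher number from compound 3 to compound 4 (1.17 log units; beyond the scatter). The direction of the step carried over from one core to the other, but its size did not: the same change on two cores in this assay, a 2.6-fold higher number (0.42 log units; beyond the scatter) from compound 1 to compound 2 and a 15-fold higher number (1.17 log units; beyond the scatter) from compound 3 to compound 4, 5.6-fold (0.75 log units) apart, beyond the scatter of two such steps. Among the compounds shown here, with only two pairs, this shows that a step measured on one core can be a poor guide to its size on the other, but it does not show what in the core sets that size or how the change would behave on a further core.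

As far as these compounds go, it remains open whether plain cyclohexyl or piperidin-4-yl on the amine nitrogen would follow the smaller step or the larger one. A longer chain in the core could also shift the size of this step in either direction.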